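The source may report more compounds than this note shows. Statements on the series, on what has been measured and on what is new or still open speak of the compounds shown alone.

In a functional assay for inhibition, with Homo sapiens as the target (a higher number here means weaker binding, a lower number tighter binding), three compounds with a shared core have been measured so far. Compound 1 `CSc1ccc(OC(C)(C)C2OCC(C/C=C\CCC(=O)O)C(c3cccnc3)O2)c([N+](=O)[O-])c1` gives 4.47 nM as its value, compound 2 `COc1ccc(OC(C)(C)C2OCC(C/C=C\CCC(=O)O)C(c3cccnc3)O2)cc1` gives 302 nM as its value and compound 3 `CC(C)(Oc1ccc(F)cc1)C1OCC(C/C=C\CCC(=O)O)C(c2cccnc2)O1` gives 120 nM as its value, the second highest of the three numbers. Compound 4 `CSc1ccccc1OC(C)(C)C1OCC(C/C=C\CCC(=O)O)C(c2cccnc2)O1` has yet to be measured. It carries 2-(methylsulfanyl)phenyl in place of 4-fluorophenyl on an oxygen on a saturated carbon.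

For the measured compounds named here, no measured step makes this exact change, but three steps at the same place bear on it. The step of a 2.5-fold lower number from compound 2 to compound 3 (0.40 log units; beyond the scatter) is modest. The steps of a 68-fold higher number from compound 1 to compound 2 (1.83 log units; beyond the scatter) and a 27-fold higher number from compound 1 to compound 3 (1.43 log units; beyond the scatter) are both large. Going by the values given here, compound 1 is the only measured compound with sulfur in this group, as compound 4 has, although the group in compound 4 is smaller. This single comparison is thin evidence, so only part of the large step of a 27-fold higher number from compound 1 to compound 3 (1.43 log units; beyond the scatter) is expected to carry over. A moderate move to a lower number is therefore expected in this assay and a 4.0-fold lower number from compound 3 to compound 4 (0.60 log units; beyond the scatter) is the estimated step. The estimate for compound 4 is 30 nM as the middle value, with 8 nM and 120 nM as the expected ends of the range.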

Compound 4, dissociation constant: 89.1 nM
Estimate against measurement, compound 4: 3.0-fold (0.47 log units) below, and the stated range covers the measured number.
By their numbers in this assay, from the lowest: compound 1; then compounds 4 and 3 (each within the scatter of the next); then compound 2.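

In this assay the change from 4-fluorophenyl to 2-(methylsulfanyl)phenyl on this oxygen gives a 1.3-fold lower number from compound 3 to compound 4 (0.13 log units; within the scatter), so placing a methylsulfanyl group on this ring does not by itself separate compound 4 from compound 3. The gap to the group of compound 1, which carries a nitro group as well as methylsulfanyl, remains wide at a 20-fold higher number from compound 1 to compound 4 (1.30 log units; beyond the scatter), while the comparison with 4-methoxyphenyl gives only a 3.4-fold lower number from compound 2 to compound 4 (0.53 log units; beyond the scatter); the three compounds without a nitro group thus stay within modest steps of one another, and compound 1 alone stands apart from them. No measurement shown here gives a reason for these differences.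

The compounds shown do not tell whether the low number of compound 1 belongs to the nitro group alone, to the nitro and methylsulfanyl groups together, or to where the methylsulfanyl group sits on the ring. They also leave open what a phenyl carrying only a nitro group would give, and whether a nitrile or an amine in place of that nitro group would keep the number of compound 1.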